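Restoring an aryl ring at the benzylic position

The compounds below may be only part of what the source reports. "The series", "measured", "known", "first", "only" and "open" are said of these compounds alone.

Compound 1 `NC(N)=NC(=O)c1nc(Cl)c(NCc2ccccc2Cl)nc1N` gives 90%.
Compound 2 `C=CCNc1nc(N)c(C(=O)N=C(N)N)nc1Cl` gives 78%.

Both numbers come from an assay for inhibition of acid-sensing ion channel 3 (Homo sapiens), read by patch clamp, tested at 20 uM; on this read-out lower numbers stand for less inhibition and higher numbers for more inhibition at the one concentration tested (going by the name of the read-out). For the measured compounds named here, compound 2 stands lowest of the two, with compound 1 its nearest neighbour, as the one measured step shows: a number 12 percentage points lower from compound 1 to compound 2 (beyond the scatter). Compound 3 `NC(N)=NC(=O)c1nc(Cl)c(NCc2ccc(Cl)cc2)nc1N` is not yet measured; it differs from compound 2 by 4-chlorophenyl in place of vinyl on a saturated chain carbon bound to a nitrogen on an aromatic ring. Going by the values given here, only that single step bears on this change, and it went beyond the scatter when the aryl ring was removed. Putting an aryl ring back in compound 3 is therefore expected to raise inhibition by roughly a number 10 percentage points higher from compound 2 to compound 3 (within the scatter). Compound 3 is estimated at 88%, in the range 76% to 96%.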

Compound 3, a percentage reported as inhibition, at one concentration (the size of the read-out at that concentration, not a potency): 97%
Compound 3: the middle estimate sits 9 percentage points below what was measured, and the stated range ends below it.
By their numbers in this assay, from the lowest: compound 2; then compounds 1 and 3 (each within the scatter of the next).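

In this assay a second chlorophenyl group now stands apart from vinyl on a saturated chain carbon bound to a nitrogen on an aromatic ring, with a number 19 percentage points higher from compound 2 to compound 3 (beyond the scatter) as the step. Changing the group from 2-chlorophenyl to 4-chlorophenyl gives a number 7 percentage points higher from compound 1 to compound 3 (within the scatter) and so separates neither compound from the other. No supporting data explain these results. Going by these compounds, whether plain phenyl, a longer chain or a carboxylic acid at this place would keep the inhibition remains open. Readings at one concentration also leave open how the potencies of these compounds compare.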